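Working notes: bromo in place of chloro

The compounds below may be only part of what the source reports. "The series", "measured", "known", "first", "only" and "open" are said of these compounds alone.

Measured so far:
- compound 1 `CCN1CCN(c2ccc(S(=O)(=O)Oc3ccccc3OC)cc2)C1=O`: > 100000 nM (a limit)
- compound 2 `CCN1CCN(c2ccc(S(=O)(=O)Oc3cccc(Cl)c3)cc2)C1=O`: 6800 nM

Both values come from a functional assay on HT-29 cells (Homo sapiens) for antiproliferative activity, read by sulforhodamine B assay, with a stated time of 48 h; on this read-out higher numbers stand for weaker inhibition and lower numbers for stronger inhibition. For compound 1, > 100000 nM is a limit and not a number. Within the data shown here, compound 2, at 6800 nM, holds the only actual number so far.

The next compound is compound 3 `CCN1CCN(c2ccc(S(=O)(=O)Oc3cccc(Br)c3)cc2)C1=O`, with bromo in place of chloro on an aromatic carbon. This places bromo in place of chloro on an aromatic carbon, meta to a large group.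

Among the measured compounds shown here, the only measured step, an at least 14-fold lower number from compound 1 to compound 2 (1.16 log units; beyond the scatter), put 3-chlorophenyl in place of 2-methoxyphenyl on an oxygen. That step is large, but it is a different change and sets no size for this one. For the measured compounds named here, no measured step exchanges chloro for bromo.

With compound 2 at 6800 nM as the anchor, no step beyond the scatter is expected in this assay. The estimated step is a 1.2-fold lower number from compound 2 to compound 3 (0.09 log units; within the scatter). For compound 3 the expected value is 5500 nM, with an estimated range of 2000 nM to 15000 nM.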

Compound 3, half-maximal inhibitory concentration: 3800 nM
Beside the measured number, compound 3's estimate is 1.4-fold (0.16 log units) above it; the measured number falls inside the stated range.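

In this assay, among these compounds, exchanging one halogen for the other on this aromatic carbon gives no step that stands clear of the scatter: a 1.8-fold lower number from compound 2 to compound 3 (0.25 log units; within the scatter). Chloro and bromo are therefore not told apart at this position, and the second halogen gives a result on the same scale as the first when set against the 2-methoxyphenyl compound: an at least 26-fold lower number from compound 1 to compound 3 (1.42 log units; beyond the scatter). Compound 1 stands at a limit and not a number, and the size of that step stays open upward: the limit of > 100000 nM in this assay, at which 1 of the 3 values shown sits.

Both large steps change the group and its place on the phenyl ring together, so the two contributions remain unseparated. From the compounds shown here alone, whether fluoro, a nitrile or an amine in the place of these halogens would hold the same level also remains open.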